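The compounds below may be only part of what the source reports. "The series", "measured", "known", "first", "only" and "open" are said of these compounds alone.

In a functional assay on PANC-1 cells (Homo sapiens) for inhibition, read by XTT assay, with a stated time of 72 h (a lower number here means a stronger inhibitor, a higher number a weaker inhibitor), compound 1 `CC(C)(C)OC(=O)N1CCC[C@H]1COCCCCCCCC/C=C/c1ccc(-c2ccccc2)cc1` gives 90000 nM and compound 2 `CC(C)(C)OC(=O)N1CCC[C@H]1COCCCCCCCCC/C=C/c1ccc(-c2ccccc2)cc1` gives 80000 nM, two values within the scatter of each other. Compound 3 `CC(C)(C)OC(=O)N1CCC[C@H]1COCCCCCCCCC/C=C/c1ccc(Oc2ccccc2)cc1` gives > 100000 nM, which is a limit of the assay and not a number. Its position is therefore known only as that limit, and no exact value can serve as a starting point.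

Compound 4 `CC(=O)N1CCC[C@H]1COCCCCCCCCC/C=C/c1ccc(Oc2ccccc2)cc1` differs from compound 3 by methyl in place of tert-butoxy on a carbonyl carbon, or tert-butoxycarbonyl to acetyl.

For the measured compounds named here, the only measured step is an at least 1.2-fold higher number from compound 2 to compound 3 (0.09 log units; that floor lies within the scatter), with phenoxy in place of phenyl on an aromatic carbon. It is a different change and does not touch the group on the carbonyl carbon, so it offers no direct measure for this one. The data hold no measured replacement at that carbonyl carbon. Going by the values given here, only the closeness of the three results in this assay gives any guide, so no step clearly beyond the scatter is expected, and a small move towards a lower number is the working assumption.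

The expected step is an at least 1.2-fold lower number from compound 3 to compound 4 (0.09 log units; that floor lies within the scatter). For compound 4 the estimate is 80000 nM, with an expected range of 30000 nM to 100000 nM.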

Compound 4, half-maximal inhibitory concentration: 65000 nM
Compound 4: middle estimate off by 1.2-fold (0.09 log units), on the high side, and the stated range covers the measured number.
By their numbers in this assay, from the lowest: compounds 4, 2 and 1 (each within the scatter of the next). At a limit, above all of these: compound 3.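

For the compounds shown here, the change from tert-butoxycarbonyl to acetyl is the first one read at this carbonyl carbon: in this assay, methyl (1 heavy atom) in place of tert-butoxy (5 heavy atoms) gives an at least 1.5-fold lower number from compound 3 to compound 4 (0.18 log units; that floor lies within the scatter), so the smaller group brings no measurable loss in this phenoxy pair. Compound 3 gives > 100000 nM in this reading, which is a limit of the assay and not a number. Going by these compounds, the size of the step therefore stays open, and only its floor is known: the limit of > 100000 nM in this assay, at which 1 of the 4 values shown sits.

Still open, on these data alone, is whether any group at the amide-type nitrogen in the ring can move the number clearly beyond the scatter, for instance a free amine with no carbonyl at all, or a urea or a longer acyl chain in place of acetyl. As far as these compounds go, it is also open whether tert-butoxycarbonyl to acetyl gives a step of similar size on the phenyl-bearing compound 2, so the result holds for this one pair and not yet as a trend.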